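The source may hold more compounds than are shown below. What is called first, only, known or untested is meant among the compounds shown, and "the series" means these compounds.

Measured compounds:
Compound 1 `N#CCNC(=O)CN(Cc1ccccc1)C(=O)c1ccc(-c2ccccc2)cc1` gives 6310 nM in an assay for inhibition of cathepsin S (Homo sapiens), read by fluorescence; on this read-out higher numbers stand for weaker inhibition and lower numbers for stronger inhibition.
Compound 2 `COc1ccc(-c2ccc(C(=O)N(CC(=O)NCC#N)Cc3ccccc3)cc2)cc1` gives 794 nM in this assay.

Among the measured compounds shown here, of the two numbers in this assay, compound 2 holds the lower one; its nearest neighbour is compound 1, and the step of a 7.9-fold lower number from compound 1 to compound 2 (0.90 log units; beyond the scatter) is the only measured step in the set.

Compound 3 `COc1ccc(-c2ccc(C(=O)N(CC(=O)NC3(C#N)CC3)Cc3ccccc3)cc2)cc1` differs from compound 2 in one place: 1-cyanocyclopropyl in place of cyanomethyl on an amide-type nitrogen. For the measured compounds named here, no measured step bears on this change. Going by the values given here, the one step on record, a 7.9-fold lower number from compound 1 to compound 2 (0.90 log units; beyond the scatter), concerns a substituent on an aromatic carbon and says nothing about the group on the amide-type nitrogen, so the size and direction of the step in this assay cannot be read from the data. With nothing to set the direction, the expectation for compound 3 is a number near that of compound 2, with a wide range on either side. The expected step from compound 2 to compound 3 is a 1.4-fold lower number from compound 2 to compound 3 (0.15 log units; within the scatter), which is not beyond the scatter. For compound 3 the estimate in this assay is 560 nM, with a range from 100 nM to 3000 nM.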

Compound 3, inhibition constant: 3980 nM
For compound 3 the middle estimate is 7.1-fold (0.85 log units) below the measured one; the whole stated range lies below it.
By their numbers in this assay, from the lowest: compound 2; then compounds 3 and 1 (each within the scatter of the next).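

Among the compounds shown here, the replacement of cyanomethyl by 1-cyanocyclopropyl on the amide-type nitrogen is the first change at this position, and in this assay it moves toward weaker inhibition, with a 5.0-fold higher number from compound 2 to compound 3 (0.70 log units; beyond the scatter), in contrast to the only earlier step, which concerned a substituent on an aromatic carbon. The two groups have the same counts of hydrogen-bond donors and acceptors, the same single triple bond and no net charge, and they differ in the three-membered carbon ring and in heavy atoms, yet the step still lies beyond the scatter, so this position does not tolerate every change that keeps those counts. No measurement on hand accounts for this loss.

The compounds shown leave open whether the same step would appear on the core of compound 1, which lacks the methoxy group, since only the methoxy-bearing core carries both groups. They also leave open how the number would respond to other groups on this nitrogen, such as 1-cyanocyclobutyl or the open-chain 1-cyano-1-methylethyl, and so whether the ring itself or simply the substitution on the carbon bearing the nitrile goes with the higher number.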